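The source may hold more compounds than are shown below. What is called first, only, known or untested is meant among the compounds shown, and "the series" means these compounds.

Of the compounds shown here, three sharing one core have been tested in a functional assay on DU-145 cells (Homo sapiens) for cytotoxicity, read by sulforhodamine B assay, with a stated time of 48 h; a lower number here means a stronger inhibitor of growth, a higher number a weaker inhibitor of growth. Compound 1 `N#Cc1ccc(Nc2nc(Oc3ccnc4ccccc34)nc(N3CCCCC3)n2)cc1C(F)(F)F` gives 94900 nM there. Compound 2 `COc1ccc(CN2CCN(c3nc(Nc4ccc(C#N)c(C(F)(F)F)c4)nc(Oc4ccnc5ccccc45)n3)CC2)c(OC)c1OC` reaches only the limit of the assay, > 100000 nM, and so yields no number. Compound 3 `N#Cc1ccc(Nc2nc(Oc3ccnc4ccccc34)nc(N3CCN(C(c4ccccc4)c4ccc(Cl)cc4)CC3)n2)cc1C(F)(F)F` likewise reaches only the limit, > 100000 nM. Going by the values given here, compound 1 therefore stands as the one compound with a measured number among the three, and that number sits close to the limit of > 100000 nM in this assay, at which 2 of the 3 values shown sit. Compound 4 `CC1CC(C)CN(c2nc(Nc3ccc(C#N)c(C(F)(F)F)c3)nc(Oc3ccnc4ccccc34)n2)C1` has not yet been measured in this assay. It differs from compound 1 in one place (3,5-dimethylpiperidin-1-yl in place of piperidin-1-yl on an aromatic carbon). No step between two measured compounds is shown, so there is nothing from which the effect of this change can be read. The expected step of a 1.0-fold higher number from compound 1 to compound 4 (0.00 log units; within the scatter) is therefore one of no change beyond the usual scatter, in either direction. Compound 4 is accordingly expected to give about 95000 nM, within a range from 40000 nM to 200000 nM, with a real chance that only a limit is reported.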

Compound 4, concentration for 50% growth inhibition: 27200 nM
The estimate for compound 4 lay 3.5-fold (0.54 log units) above the measured number, outside the stated range (below it).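

Going by these compounds alone, replacing piperidin-1-yl with 3,5-dimethylpiperidin-1-yl gives a 3.5-fold lower number from compound 1 to compound 4 (0.54 log units; beyond the scatter) in this assay, the first step that can be read. It shows that the group at this position on the shared core can change growth inhibition beyond the scatter, although the step is modest and compound 4, at 27200 nM, remains a weak inhibitor of growth. Part of the series still gives no number, only a limit of the assay: the limit of > 100000 nM in this assay, at which 2 of the 4 values shown sit.

A single step cannot show whether the gain depends on the added methyl groups themselves, on where they sit on the ring, or on the particular isomer tested. It also leaves open how other groups at this position would behave, such as morpholine, 4-methylpiperidine or an open-chain diethylamino group.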